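The compounds below may be only part of what the source reports. "The series", "measured", "known", "first", "only" and "open" are said of these compounds alone.

Three compounds on the shared core have values in a functional assay on HepG2 cells (Homo sapiens) for cytotoxicity, read by MTT assay, with a stated time of 48 h; a higher number here means a weaker inhibitor, a lower number a stronger inhibitor: compound 1 `COc1ccccc1-c1nnc(SCCn2c([N+](=O)[O-])cnc2C)o1` gives 10000 nM, compound 2 `Cc1ncc([N+](=O)[O-])n1CCSc1nnc(-c2ccc(Cl)cc2)o1` gives 7800 nM and compound 3 `Cc1ccc(-c2nnc(SCCn3c([N+](=O)[O-])cnc3C)o2)c(O)c1` gives 16600 nM. Two steps fix the position of compound 3: a 1.7-fold higher number from compound 1 to compound 3 (0.22 log units; within the scatter), and a 2.1-fold higher number from compound 2 to compound 3 (0.33 log units; beyond the scatter). It therefore separates from compound 2 only, and only modestly.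

Compound 4 `Cc1ncc([N+](=O)[O-])n1CCSc1nnc(-c2ccc(N)nc2)o1` has no value yet. Its change is confined to one substituent: 6-aminopyridin-3-yl in place of 2-hydroxy-4-methylphenyl on an aromatic carbon. In words, 6-aminopyridin-3-yl stands in place of 2-hydroxy-4-methylphenyl on an aromatic carbon.

All three measured steps change this same place, so all three bear on the question. Besides the two above, the third is a 1.3-fold lower number from compound 1 to compound 2 (0.11 log units; within the scatter). Across these different substituents the values stay close together, and only one step goes beyond the scatter, by a small margin. Among the compounds with values here, none of the measured compounds carries a ring with a hetero atom at this place, so the direction of the new step has no direct support. No step beyond the scatter is therefore expected in this assay.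

The expected change is a 1.3-fold lower number from compound 3 to compound 4 (0.11 log units; within the scatter), an estimate only. For compound 4 the estimated value is 13000 nM, with an expected range from 5500 nM to 30000 nM.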

Compound 4, half-maximal inhibitory concentration: 9400 nM
Estimate against measurement, compound 4: 1.4-fold (0.14 log units) above; the range from low to high includes it.
By their numbers in this assay, from the lowest: compounds 2, 4, 1 and 3 (each within the scatter of the next, the first and the last beyond it).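

In this assay, within the data shown here, the 6-aminopyridin-3-yl group is the first ring at this place with a hetero atom, and it gives no step beyond the scatter against any of the three carbon-only rings: a 1.8-fold lower number from compound 3 to compound 4 (0.25 log units; within the scatter) and a 1.2-fold higher number from compound 2 to compound 4 (0.08 log units; within the scatter) and also a 1.1-fold lower number from compound 1 to compound 4 (0.03 log units; within the scatter). The one step beyond the scatter in the series remains the modest 2.1-fold higher number from compound 2 to compound 3 (0.33 log units; beyond the scatter), so a six-membered aromatic ring with a hetero atom on the aromatic carbon of the five-membered ring falls within the same narrow band of values as the carbon-only rings, and this position has so far shown little sensitivity to the change of ring. No measurement at hand accounts for any of these steps.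

A plain pyridin-3-yl group would show whether the ring nitrogen or the amine of compound 4 contributes anything to this reading, since the two enter together here. Going by these compounds, all four groups are aromatic rings, so it remains open whether a saturated ring such as morpholine, a carboxylic acid or a longer alkyl chain at this place would stay within the same band.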